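Chain-terminus variation on the shared core: notes toward compound 3

This account rests on a few compounds, and the source may have more. Where it says the series, first, only, none or still open, it means among the compounds named here.

Measured so far:
compound 1 `O=c1c(-c2ccc(O)cc2)coc2cc(OCCOCCOCCO)ccc12` — 40 nM
compound 2 `NCCCCOc1ccc2c(=O)c(-c3ccc(O)cc3)coc2c1` — 250 nM

In an assay (Cricetulus griseus) for inhibition of aldehyde dehydrogenase, mitochondrial (Homo sapiens) (on this read-out higher numbers stand for weaker inhibition and lower numbers for stronger inhibition), compound 1 gives 40 nM and stands lowest of the two numbers; the nearest is compound 2, which gives 250 nM. Going by the values given here, the one measured step is a 6.3-fold higher number from compound 1 to compound 2 (0.80 log units; beyond the scatter), so exchanging the hydroxyl-terminated ether chain for an amine-terminated carbon chain at this position weakened inhibition beyond the scatter.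

Compound 3 `O=C(O)CCCCCCOc1ccc2c(=O)c(-c3ccc(O)cc3)coc2c1` is not yet measured. Relative to compound 1 the change is 4-carboxybutyl in place of 2-(2-hydroxyethoxy)ethoxy on a saturated chain carbon, two bonds along the chain from an oxygen on an aromatic ring. The step from compound 1 to compound 2 is the only one that bears on it: it also replaces the same chain on the same carbon, but with a different terminal group, so it sets the direction rather than the size. Among the compounds with values here, a carboxyl terminus on a carbon chain is a new variation with no direct precedent here. Compound 3 is therefore expected to give 90 nM in this assay, within 25 nM to 320 nM, meaning an estimated step of a 2.3-fold higher number from compound 1 to compound 3 (0.35 log units; beyond the scatter) from compound 1 to compound 3, a weakening smaller than that seen for compound 2.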

Compound 3, half-maximal inhibitory concentration: 50 nM
Compound 3: the middle estimate sits 1.8-fold (0.26 log units) above what was measured, and the stated range covers the measured number.
By their numbers in this assay, from the lowest: compounds 1 and 3 (each within the scatter of the next); then compound 2.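

Compound 3 shows that this position does not depend on the ether chain of compound 1: in this assay the 4-carboxybutyl group in place of 2-(2-hydroxyethoxy)ethoxy gives a 1.3-fold higher number from compound 1 to compound 3 (0.10 log units; within the scatter), so the two chains cannot be told apart on this read-out. A carbon chain stands on both sides of the other new step, in which the 2-carboxyethyl group in place of amino gives a 5.0-fold lower number from compound 2 to compound 3 (0.70 log units; beyond the scatter). This step alters the chain terminus and the chain length together. Among these compounds, a hydroxyl-ended ether chain and a carboxyl-ended carbon chain sit within the scatter of each other, and only the amine-ended chain of compound 2 stands apart, while no measurement in hand accounts for any of these differences.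

Still open, going by these compounds, is whether the terminal group or the chain length drives the gap, which an amine on a chain as long as that of compound 3, or a carboxylic acid on a chain as short as that of compound 2, would separate. On these data alone, it is also open whether the carboxylic acid itself matters, a question that a methyl ester or a primary amide at the same terminus would address.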